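A few compounds are considered here, and "the series" means these few. Any claim that something is new, unique, unknown or untested is made for them only; others in the source may bear on it.

Series notes. Compound 1 `COc1ccc(-c2cc(/C=C/C(=O)c3ccc(N)cc3)[nH]n2)cc1`, compound 2 `COc1ccc(-c2cc(/C=C/C(=O)c3ccc(N)cc3)[nH]n2)cc1OC` and compound 3 `COc1cc(C(=O)/C=C/c2cc(-c3cc(OC)c(OC)c(OC)c3)n[nH]2)cc(OC)c1OC` have been run in a functional assay on A498 cells (Homo sapiens) for cytotoxicity, read by sulforhodamine B assay, with a stated time of 48 h, tested at 0.01 uM; a lower number here means a stronger effect, a higher number a weaker effect of the compound at the concentration tested. Compound 1 gives 88%, compound 2 gives 95% and compound 3 gives 95%. The step of a number 7 percentage points lower from compound 2 to compound 1 (within the scatter) corresponds to hydrogen in place of methoxy on an aromatic carbon. The difference between the cores of compound 2 and compound 3 is not broken down here; their two values are level at the digits given. Compound 4 `COc1ccc(-c2cc(/C=C/C(=O)c3cc(OC)c(OC)c(OC)c3)[nH]n2)cc1OC` is not yet measured; it arises from compound 3 by hydrogen in place of methoxy on an aromatic carbon. This is the same kind of change as that from compound 2 to compound 1, though here the place is additionally meta to a methoxy group. The earlier step was a number 7 percentage points lower from compound 2 to compound 1 (within the scatter). Because compound 3 stands at 95%, the expected step is a number 5 percentage points lower from compound 3 to compound 4 (within the scatter). Compound 4 is therefore estimated at 90%, with a range of 80% to 98%.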

Compound 4, a percentage reported as activity, at one concentration (the size of the read-out at that concentration, not a potency): 99%
Estimate against measurement, compound 4: 9 percentage points below; measured number above the stated range.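

In this assay, hydrogen in place of methoxy on an aromatic carbon gives a number 4 percentage points higher from compound 3 to compound 4 (within the scatter). Set beside the earlier step, the same change on the other core does not separate from it: the same change on two cores in this assay, a number 7 percentage points lower (within the scatter) from compound 2 to compound 1 and a number 4 percentage points higher (within the scatter) from compound 3 to compound 4, 11 percentage points apart, within the scatter of two such steps. Both steps lie within the scatter, so no effect of the change is shown on either core, and nothing shows that the two cores would respond alike at any other concentration.

Still open, from the compounds shown here alone, is whether another group on that aromatic carbon, such as a carboxylic acid or a nitrile, would move the read-out beyond the scatter. Also open, going by these compounds, is how this methoxy change reads on a compound with a clearly stronger effect in this assay.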